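Smaller Aryl Group on the Shared Core: Compound 3

The source may hold more compounds than are shown below. What is called first, only, known or untested is meant among the compounds shown, and "the series" means these compounds.

Compound 1 `Cc1oc(-c2c(C)c(C)c(C)c(C)c2C)nc1CN1CCC(C(=O)NCCCN2C[C@H](C)C[C@H](C)C2)CC1` gives 455 10^-6 cm/s in a physicochemical assay for permeability, using PAMPA (a higher number here means that the compound crosses the layer faster, a lower number that the compound crosses the layer more slowly), the higher of the two numbers at hand. Compound 2 `Cc1ccccc1-c1nc(CN2CCC(C(=O)NCCCN3CCCC(CC(C)C)C3)CC2)c(C)o1` gives 3 10^-6 cm/s in this assay, a far lower value, well beyond the scatter. Compound 3 `COc1cccc(C)c1-c1nc(CN2CCC(C(=O)NCCCN3C[C@H](C)C[C@H](C)C3)CC2)c(C)o1` differs from compound 1 in one place: 2-methoxy-6-methylphenyl in place of 2,3,4,5,6-pentamethylphenyl on an aromatic carbon. Among the measured compounds shown here, no pair of measured compounds isolates this change. The account nonetheless expects a clear drop, well beyond the scatter, in moving from compound 1 to compound 3, namely a 7.6-fold lower number from compound 1 to compound 3 (0.88 log units; beyond the scatter). Compound 3 is therefore estimated at 60 10^-6 cm/s, with a plausible range from 10 10^-6 cm/s to 300 10^-6 cm/s.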

Compound 3, apparent permeability: 198 10^-6 cm/s
Compound 3: middle estimate off by 3.3-fold (0.52 log units), on the low side; measured number inside the range.
By their numbers in this assay, from the lowest: compound 2; then compound 3; then compound 1.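

Swapping 2,3,4,5,6-pentamethylphenyl for 2-methoxy-6-methylphenyl gives the first step read at this aromatic carbon in this assay: a 2.3-fold lower number from compound 1 to compound 3 (0.36 log units; beyond the scatter), modest in size but beyond the scatter. The aryl group at this position can therefore change the read-out with the rest of the molecule held constant, and this one exchange lowers the number without removing the aromatic ring. Nothing measured here bears on the reason for this step.

This single step cannot separate the entry of the methoxy group from the loss of ring methyl groups. From the compounds shown here alone, how a plain phenyl group or an ethoxy group at this position would read remains open.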